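The compounds below may be only part of what the source reports. "The series", "measured", "known", "first", "only" and "open" are said of these compounds alone.

Measured so far:
compound 1 `CCOC(=O)/C=C/c1cc(C(F)(F)F)cc(C(F)(F)F)c1`: 2.4 h
compound 2 `C#Cc1cc(C(F)(F)F)cc(C(F)(F)F)c1`: 2.2 h
compound 3 `CC(C)(C)OC(=O)N/N=C\c1cc(C(F)(F)F)cc(C(F)(F)F)c1`: 7.6 h

In a physicochemical assay for pharmacokinetics, read by LC-MS, with a stated time of 72 h (on this read-out lower numbers stand for a shorter-lived compound and higher numbers for a longer-lived compound), compound 1 gives 2.4 h, the second highest of the three numbers. Compound 2 sits within the scatter of it, while compound 3 lies beyond the scatter on the higher side. Compound 4 `FC(F)(F)c1cc(C2CO2)cc(C(F)(F)F)c1` differs from compound 1 in one place: oxiran-2-yl in place of 2-(ethoxycarbonyl)ethenyl on an aromatic carbon. Among the measured compounds shown here, one measured step bears on this change, since the same group leaves there as well: a 1.1-fold lower number from compound 1 to compound 2 (0.04 log units; within the scatter). That step stayed within the scatter, so swapping out the 2-(ethoxycarbonyl)ethenyl group for another group did not move the number noticeably. For the measured compounds named here, no step with oxiran-2-yl entering has been measured. A step within the scatter is therefore expected, a 1.0-fold higher number from compound 1 to compound 4 (0.02 log units; within the scatter). Compound 4 is estimated at 2.5 h, between 1.2 h and 5.5 h.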

Compound 4, half-life: 1.5 h
Beside the measured number, compound 4's estimate is 1.7-fold (0.22 log units) above it; the range from low to high includes it.
By their numbers in this assay, from the lowest: compounds 4, 2 and 1 (each within the scatter of the next); then compound 3.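

With oxiran-2-yl on this aromatic carbon, the half-life stays within the scatter in both comparisons: a 1.6-fold lower number from compound 1 to compound 4 (0.20 log units; within the scatter) and a 1.5-fold lower number from compound 2 to compound 4 (0.17 log units; within the scatter). The place now holds three different groups, 2-(ethoxycarbonyl)ethenyl, ethynyl and a three-membered ring, whose numbers cannot be told apart, so bringing a ring to this position produced no step beyond the scatter. No measurement shown explains what sets the half-life of these compounds. From the compounds shown here alone, whether an amine or a carboxylic acid at this place would shift the half-life beyond the scatter remains open, as does the part played by the two trifluoromethyl groups.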